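Swapping a cyclopropyl for a methoxymethyl: expected lipophilicity

The source may hold more compounds than are shown below. What is called first, only, known or untested is meant among the compounds shown, and "the series" means these compounds.

Measured so far in a physicochemical assay for lipophilicity; on this read-out lower numbers stand for lower lipophilicity and higher numbers for higher lipophilicity:
compound 1 `CC1CCCN(Cc2c(-c3nnc(SC(C)C)n3-c3ccccc3)n(C)c3ccc(F)cc23)C1` gives 6.18
compound 2 `COc1cccc(CNCc2c(-c3nnc(SC(C)C)n3-c3ccccc3)n(C)c3ccc(F)cc23)c1` gives 6.42
compound 3 `CC(C)Sc1nnc(-c2c(CNCC3CC3)c3cc(F)ccc3n2C)n1-c1ccccc1` gives 5.4

Compound 3 stands lowest of the three; the gap a number 0.78 log units lower from compound 1 to compound 3 (beyond the scatter) and the gap a number 1.02 log units lower from compound 2 to compound 3 (beyond the scatter) both exceed the scatter, while a number 0.24 log units higher from compound 1 to compound 2 (within the scatter) does not. Compound 4 `COCCNCc1c(-c2nnc(SC(C)C)n2-c2ccccc2)n(C)c2ccc(F)cc12` is not yet measured. The change from compound 3 is methoxymethyl in place of cyclopropyl on a saturated chain carbon bound to an amine nitrogen. The step that bears most on it is the exchange at the same place, a number 1.02 log units lower from compound 2 to compound 3 (beyond the scatter), though there a ring of six carbons left; here a three-carbon ring leaves and an oxygen enters, so a smaller downward step in this assay is expected. Compound 4 is therefore estimated at 4.7, ranging from 4.2 to 5.3, with an expected step of a number 0.70 log units lower from compound 3 to compound 4 (beyond the scatter).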

Compound 4, partition coefficient: 4.52
For compound 4 the middle estimate is 0.18 log units above the measured one; the measured number falls inside the stated range.
By their numbers in this assay, from the lowest: compound 4; then compound 3; then compounds 1 and 2 (each within the scatter of the next).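

In this assay, methoxymethyl in place of cyclopropyl, with the same number of heavy atoms, gives a number 0.88 log units lower from compound 3 to compound 4 (beyond the scatter), so this position responds to more than group size as counted in heavy atoms. The steps grow to a number 1.90 log units lower from compound 2 to compound 4 (beyond the scatter) and a number 1.66 log units lower from compound 1 to compound 4 (beyond the scatter), which leaves compound 4 lowest of the four. Nothing available explains these steps. On these data alone, whether the lost ring or the added oxygen matters more stays open, and an ethyl group at this place would help separate them. As far as these compounds go, how a longer ether chain or a carboxylic acid there would read is also open.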